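Amide to acid on the aryl thiazole ether series

A few compounds are considered here, and "the series" means these few. Any claim that something is new, unique, unknown or untested is made for them only; others in the source may bear on it.

Measured compounds:
compound 1, `COc1cc(OCc2csc(-c3ccc(C(C)(C)O)cc3)n2)c2cc(-c3cn4nc(OC)sc4n3)oc2c1`, 1.83 h
compound 2, `COc1cc(OCc2cccc(-c3ccc(OC)nc3)c2)c2cc(-c3cn4nc(OC)sc4n3)oc2c1`, 0.733 h
compound 3, `CNC(=O)c1ccc(-c2nc(COc3cc(OC)cc4oc(-c5cn6nc(OC)sc6n5)cc34)cs2)cc1`, 0.983 h

In an ADME assay on microsomes from liver (Homo sapiens) for metabolic stability (a higher number here means that the compound lasts longer, a lower number that the compound disappears faster), compound 3 gives 0.983 h, which places it second among the three numbers. Its nearest neighbour is compound 2, whose value in this assay is 0.733 h; the furthest is compound 1, which in this assay gives 1.83 h. Both gaps are within the scatter, so no order among the three can be claimed.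

The unmeasured compound 4, `COc1cc(OCc2csc(-c3ccc(C(=O)O)cc3)n2)c2cc(-c3cn4nc(OC)sc4n3)oc2c1`, differs from compound 3 in one place: hydroxy in place of methylamino on a carbonyl carbon. For the measured compounds named here, no measured step covers this change. Going by the values given here, the only single-point step available, a 1.9-fold lower number from compound 1 to compound 3 (0.27 log units; within the scatter), concerns a different exchange at the same carbonyl carbon and is itself within the scatter. The series therefore gives no direct guide for replacing methylamino by hydroxy, and the expectation must rest on the general closeness of all three values in this assay.

Compound 4 is accordingly expected to lie near the others, with an estimated step of a 1.4-fold higher number from compound 3 to compound 4 (0.15 log units; within the scatter). The estimate for compound 4 in this assay is 1.4 h, with a range from 0.6 h to 3.5 h.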

Compound 4, half-life: > 2 h
Compound 4 gave a limit, no number (the forecaster's own chance of this, stated with the estimate: 10%); middle value at least 1.4-fold (0.15 log units) from the limit.
By their numbers in this assay, from the lowest: compounds 2, 3 and 1 (each within the scatter of the next, the first and the last beyond it). At a limit, above all of these: compound 4.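

Compound 4 carries carboxy where compound 3 carries methylcarbamoyl, and in this assay compound 4 gives > 2 h, which is a limit of the assay and not a number. Hydroxy in place of methylamino on the carbonyl carbon comes to an at least 2.0-fold higher number from compound 3 to compound 4 (0.30 log units; that floor lies within the scatter), and carboxy in place of 1-hydroxy-1-methylethyl on the aromatic carbon comes to an at least 1.0-fold higher number from compound 1 to compound 4 (0.03 log units; that floor lies within the scatter). For the compounds shown here, the earlier compounds showed only one exchange at this place, while neither floor now points to a shorter half-life with carboxy there, and the series gains its first reading that is open upward: the limit of > 2 h in this assay, at which 1 of the 4 values shown sits.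

On these data alone, how far the true half-life of compound 4 lies from those of compound 1 and compound 3 stays open, as does whether either gap goes beyond the scatter. Also open, as far as these compounds go, is whether a primary carboxamide, a methyl ester or a sulfonamide on the same aromatic carbon would read like carboxy or like methylcarbamoyl in this assay.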